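Swapping a Sulfonyl Group for a Sulfanyl Group

A few compounds are considered here, and "the series" means these few. Any claim that something is new, unique, unknown or untested is made for them only; others in the source may bear on it.

In a functional assay on DU-145 cells (Homo sapiens) for inhibition, read by trypan blue exclusion, with a stated time of 96 h (on this read-out higher numbers stand for weaker inhibition of growth and lower numbers for stronger inhibition of growth), compound 2 `O=C(/C(=C\c1ccccc1OCc1ccccc1)S(=O)(=O)c1ccc(F)cc1)c1ccc(Cl)cc1` gives 1000 nM. For the measured compounds named here, that is level with compound 1 `COc1ccccc1/C=C(/SCc1ccc(Cl)cc1)C(=O)c1ccc(Cl)cc1` at 1000 nM, and the two share the lowest number of the three measured so far. Compound 3 `Cc1ccc(CS(=O)(=O)/C(=C/c2sccc2C)C(=O)c2ccc(Cl)cc2)cc1` stands much higher at 25000 nM, which means weaker growth inhibition.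

The next molecule to test is compound 4 `O=C(/C(=C\c1ccccc1OCc1ccccc1)Sc1ccc(Br)cc1)c1ccc(Cl)cc1`. It has (4-bromophenyl)sulfanyl in place of (4-fluorophenyl)sulfonyl on a double-bonded chain carbon bound to a carbonyl carbon and a double-bonded chain carbon.

Going by the values given here, no two measured compounds differ in one place only, so the size of this swap has not been observed directly. The closest guide is compound 1, which carries a sulfanyl group rather than a sulfonyl group and still gives 1000 nM. Like compound 2, compound 3 carries a sulfonyl group yet gives 25000 nM, so the sulfur group alone does not set the number across this small set. In this assay, no step beyond the scatter is expected. The estimated change is a 1.2-fold higher number from compound 2 to compound 4 (0.08 log units; within the scatter). For compound 4, the expected value is 1200 nM, with an estimated range from 300 nM to 6000 nM.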

Compound 4, concentration for 50% growth inhibition: 10000 nM
Compound 4: middle estimate off by 8.3-fold (0.92 log units), on the low side; the measured number lies above the stated range.
By their numbers in this assay, from the lowest: compounds 1 and 2 (each within the scatter of the next); then compound 4; then compound 3.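

In this assay, putting (4-bromophenyl)sulfanyl in place of (4-fluorophenyl)sulfonyl on a double-bonded chain carbon bound to a carbonyl carbon and a double-bonded chain carbon gives a 10-fold higher number from compound 2 to compound 4 (1.00 log units; beyond the scatter), which means weaker inhibition of growth. For the compounds shown here, this is the first comparison in the set between compounds that differ in one place only, and it shows that the group at this position can change the result, at least on the shared core of these two compounds. Nothing measured here explains the loss, so the step stands as an observation without a known cause.

The swap alters the sulfur group and the halogen on the ring together, so the compounds shown leave open which of the two changes carries the step, or whether both contribute. A compound with (4-fluorophenyl)sulfanyl or (4-bromophenyl)sulfonyl at this position would separate the two changes, and one with an amine on the ring in place of the halogen would show whether this position accepts a very different kind of group.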